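This account rests on a few compounds, and the source may have more. Where it says the series, first, only, none or still open, it means among the compounds named here.

Working notes on the chain series. In a functional assay on HCT-116 cells (Homo sapiens) for antiproliferative activity, read by MTT assay, with a stated time of 48 h (a higher number here means a weaker inhibitor, a lower number a stronger inhibitor), compound 1 (`CCCCC(CCO)n1cnc2c(Cl)nc(F)nc21`) gives 13500 nM and compound 2 (`CCCCCC(CCO)n1cnc2c(Cl)nc(F)nc21`) gives 8660 nM. For the measured compounds named here, these two values lie within the scatter of each other, so compound 2 has no clear separation from the only other measured compound. Compound 3 (`CCCCCCCCC(CCO)n1cnc2c(Cl)nc(F)nc21`) carries a longer chain on the same core, and its difference from compound 2 is propyl in place of hydrogen on a saturated chain carbon, six bonds along the chain from an aromatic nitrogen. Going by the values given here, the only measured step bearing on this is a 1.6-fold lower number from compound 1 to compound 2 (0.19 log units; within the scatter), which came from methyl in place of hydrogen on a saturated chain carbon. It is weak evidence, but the addition here is larger, so a modest move to a lower number in this assay is expected. The expected size of the change is a 2.2-fold lower number from compound 2 to compound 3 (0.34 log units; beyond the scatter). Compound 3 is estimated at 4000 nM, with an expected range of 1500 nM to 11000 nM.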

Compound 3, half-maximal inhibitory concentration: 24200 nM
Compound 3: middle estimate off by 6.1-fold (0.78 log units), on the low side; the measured number lies above the stated range.
By their numbers in this assay, from the lowest: compounds 2, 1 and 3 (each within the scatter of the next, the first and the last beyond it).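

In this assay, for the compounds shown here, the added propyl gives a 2.8-fold higher number from compound 2 to compound 3 (0.45 log units; beyond the scatter) and is the first single change to lie beyond the scatter, so chain extension at this position need not bring a lower number. Set against the start of the series, the butyl change gives a 1.8-fold higher number from compound 1 to compound 3 (0.25 log units; within the scatter) and stays within the scatter, which leaves compound 2 and compound 3 as the only separated pair and shows no steady trend with chain length across the three compounds. No available measurement accounts for this rise.

Open, on these data alone, is where, between the chains of compound 2 and compound 3, the number begins to rise, and whether a longer chain carries it higher still. Also open, as far as these compounds go, is how an amine or a carboxylic acid in place of the propyl would read.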